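A Second Chlorine Added to a Weakly Cytotoxic Core

The compounds below may be only part of what the source reports. "The series", "measured", "known", "first", "only" and "open" are said of these compounds alone.

Compound 1 `ClCc1ccc(Cn2cnc3c(Cl)ncnc32)cc1` was tested in a functional assay on PC-3 cells (Homo sapiens) for cytotoxicity, read by sulforhodamine B assay, with a stated time of 48 h; a lower number here means that less compound is tolerated, a higher number that more compound is tolerated. In this assay compound 1 gives > 100000 nM, which is a limit of the assay rather than a measured number. Compound 2 `ClCc1ccccc1Cn1cnc2c(Cl)ncnc21` shares the same core, and in this assay compound 2 gives 53700 nM. Compound 3 `ClCc1ccc(Cn2cnc3c(Cl)nc(Cl)nc32)cc1` has not yet been measured. It differs from compound 1 by chloro in place of hydrogen on an aromatic carbon. Among the measured compounds shown here, no step between measured compounds is known, so there is no measured size to lean on; compound 1 stands at the limit of > 100000 nM in this assay, at which 1 of the 2 values shown sits, and for the change to compound 3 a small shift in either direction, or none beyond the scatter, is expected in this assay. Compound 3 is estimated to give 80000 nM in this assay, within a range of 30000 nM to 300000 nM. For compound 3 the estimated step is an at least 1.2-fold lower number from compound 1 to compound 3 (0.09 log units; that floor lies within the scatter).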

Compound 3, concentration lethal to 50% of the cells: 45700 nM
Compound 3: the middle estimate sits 1.8-fold (0.24 log units) above what was measured; the measured number falls inside the stated range.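

In this assay the chloro in place of hydrogen on the aromatic carbon between two ring nitrogen atoms gives an at least 2.1-fold lower number from compound 1 to compound 3 (0.34 log units; beyond the scatter) and so shows that this position can change the read-out. A single added chlorine atom, with the rest of compound 1 unchanged, is enough to take the number beyond the scatter, towards less compound being tolerated. Only a smallest possible size can be given for this step, because compound 1 sits at a limit and not at a measured number: the limit of > 100000 nM in this assay, at which 1 of the 3 values shown sits.

The compounds shown leave open whether an amine or a methoxy group at this same place would also lower the number, or whether the step belongs to chloro alone. They also leave open whether the same chloro would give a step of similar size on the core of compound 2.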